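A few compounds are considered here, and "the series" means these few. Any claim that something is new, unique, unknown or untested is made for them only; others in the source may bear on it.

In a physicochemical assay for lipophilicity, read by HPLC, at pH 7.4 (on this read-out lower numbers stand for lower lipophilicity and higher numbers for higher lipophilicity), the measured compounds are:
compound 1 `Cc1cc(Br)ccc1C(=O)Nc1ccccn1` gives 3.2
compound 2 `Cc1ccccc1C(=O)Nc1ccc(C#N)cn1` gives 3.9
compound 3 `Cc1ccccc1C(=O)Nc1ncccn1` gives 3.9

Compound 2 stands level with compound 3 at the digits shown; the two together are the highest of the three numbers, while compound 1 lies a good way lower, beyond the scatter. For the measured compounds named here, no pair of measured compounds differs in only one place, so the present change has no measured precedent. Compound 4 `COc1ccc(NC(=O)c2ccccc2C)nc1` differs from compound 2 as follows: methoxy in place of cyano on an aromatic carbon. Resting on compound 2 alone, a small rise in this assay is expected, likely no larger than the edge of the scatter. The expected step is a number 0.30 log units higher from compound 2 to compound 4 (within the scatter). Compound 4 is therefore estimated at 4.2, with a range from 3.7 to 4.7.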

Compound 4, distribution coefficient: 2.5
For compound 4 the middle estimate is 1.70 log units above the measured one, outside the stated range (below it).
By their numbers in this assay, from the lowest: compound 4; then compound 1; then compounds 2 and 3 (each within the scatter of the next).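

In this assay, for the compounds shown here, methoxy in place of cyano on an aromatic carbon, two atoms from the ring nitrogen and para to a large group, gives a number 1.40 log units lower from compound 2 to compound 4 (beyond the scatter) as the first measured step at this position. The read-out thus moves strongly at this position, even though the leaving and entering groups have equal heavy-atom and hydrogen-bond acceptor counts. Nothing measured here accounts for the size of this step. As far as these compounds go, it remains open how an amine or a longer chain at this position would read in this assay, and whether the step would recur on the core of compound 1.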